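The source may report more compounds than this note shows. Statements on the series, on what has been measured and on what is new or still open speak of the compounds shown alone.

Measured in a functional assay on MCF7 cells (Homo sapiens) for antiproliferative activity, read by MTT assay; on this read-out higher numbers stand for weaker inhibition and lower numbers for stronger inhibition:
- compound 1 `Cc1cccc(Nc2nccc(-c3ccc(Br)cc3)n2)c1`: 210000 nM
- compound 2 `COc1ccc(-c2ccnc(Nc3ccc(Cl)cc3Cl)n2)cc1`: 4170 nM
- compound 3 `Clc1ccc(Nc2nccc(-c3ccc(Cl)cc3Cl)n2)c(Cl)c1`: 3180 nM

Compound 2 lies within the scatter of compound 3, so these two cannot be ordered. Compound 1 stands well above compound 2, by a margin beyond the scatter.

The next compound to be read is compound 4 `Clc1ccc(Nc2nccc(-c3ccc(Br)cc3)n2)c(Cl)c1`, still unmeasured. Its difference from compound 2 is bromo in place of methoxy on an aromatic carbon, para to a large group.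

For the measured compounds named here, no measured pair isolates this change, so the evidence is indirect. Compound 3 also lacks the methoxy group and gives 3180 nM, which points to no step beyond the scatter in this assay. Compound 1 carries a bromo group and gives 210000 nM, which leaves some risk of a much higher number, though three compounds cannot show whether that value goes with the bromo group. The expectation is therefore a small upward step or none beyond the scatter, with the uncertainty reaching further upward than downward.

The estimated step is a 1.3-fold higher number from compound 2 to compound 4 (0.12 log units; within the scatter).

For compound 4 the expected value is 5500 nM, with an estimated range of 1800 nM to 30000 nM.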

Compound 4, half-maximal inhibitory concentration: 2490 nM
Estimate against measurement, compound 4: 2.2-fold (0.34 log units) above; low and high end bracket the measured number.
By their numbers in this assay, from the lowest: compounds 4, 3 and 2 (each within the scatter of the next); then compound 1.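

In this assay, for the compounds shown here, this pair is the first to isolate bromo in place of methoxy on an aromatic carbon, para to a large group, and it gives a 1.7-fold lower number from compound 2 to compound 4 (0.22 log units; within the scatter), so the two groups cannot be told apart at this place with the rest of the structure held constant. The bromo group therefore appears here in a compound whose number cannot be separated from that of its methoxy partner. Compound 1, at 210000 nM, also carries a bromo group but differs from compound 4 in more than one place, so no step can be read between them and its high number remains unassigned. No measurement at hand bears on why this exchange leaves the number within the scatter.

Going by these compounds, two groups say little about the full range of this aromatic carbon, so it remains open whether a plain hydrogen, an amine or a carboxylic acid there would keep the number in the same range. On these data alone, it also remains open whether bromo and methoxy would still be indistinguishable on a compound with the methyl group of compound 1 in place of the two chloro groups.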